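Methyl-bearing hydrazone gains a trifluoromethyl group

The compounds below may be only part of what the source reports. "The series", "measured", "known", "first", "only" and "open" are said of these compounds alone.

Compound 1 `CC(=O)/C(=N\Nc1ccccc1)N(C)c1cccc(Cl)c1` was tested in an assay on isolated protein for binding affinity to corticotropin-releasing factor receptor 1 (Homo sapiens) (on this read-out higher numbers stand for weaker inhibition and lower numbers for stronger inhibition), and gave only a limit, > 10000 nM, so it stands at the weak end of what this assay reports (the limit of > 10000 nM in this assay, at which 1 of the 2 values shown sits). Compound 2 `CC(=O)/C(=N\Nc1ccccc1C(F)(F)F)Nc1cccc(Cl)c1` differs from compound 1 in several places. In this assay compound 2 gives 538 nM; 538 nM (2 entries). The unmeasured compound 3 `CC(=O)/C(=N\Nc1ccccc1C(F)(F)F)N(C)c1cccc(Cl)c1` keeps the core of compound 1 and carries trifluoromethyl in place of hydrogen on an aromatic carbon. Among the compounds with values here, no single step of this kind has been measured here, so the direction rests on compound 2 alone. The change from compound 1 to compound 3 is expected to be an at least 3.3-fold lower number from compound 1 to compound 3 (0.52 log units; beyond the scatter), toward stronger binding. Compound 3 is therefore estimated at 3000 nM, between 500 nM and 20000 nM.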

Compound 3, inhibition constant: > 10000 nM
Compound 3: a limit, no number; the forecaster's own chance of this, stated with the estimate: 40%; middle value at least 3.3-fold (0.52 log units) from the limit.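

Compound 1 and compound 3 each give a limit rather than a number, so no step between them can be read: the limit of > 10000 nM in this assay, at which 2 of the 3 values shown sit.

The compounds shown leave open whether trifluoromethyl in place of hydrogen on an aromatic carbon changes binding at all on the core of compound 1.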